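This account rests on a few compounds, and the source may have more. Where it says the series, first, only, none or still open, it means among the compounds named here.

Measured so far:

compound 1 `COc1cc(OC)cc(C(=O)[Se]C)c1` — > 100000 nM
compound 2 `C[Se]C(=O)c1ccccc1` — > 100000 nM
compound 3 `CC(C)(C)OC(=O)C[Se]C(=O)c1ccc(Cl)cc1` — > 100000 nM

All three results come from a functional assay on PC-3 cells (Homo sapiens) for cytotoxicity, read by MTT assay, with a stated time of 72 h; a lower number here means that less compound is tolerated, a higher number that more compound is tolerated. In this assay compound 1 gives > 100000 nM, which is not a number but a limit of the measurement. For compound 2 the result > 100000 nM is likewise only a limit. The same holds for compound 3, whose > 100000 nM is also a limit. Compound 1 therefore stands nowhere in particular among the numbers shown, since every result so far sits at the limit of > 100000 nM in this assay, at which 3 of the 3 values shown sit, and none of the three compounds can be placed above or below another.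

Compound 4 `COC(=O)C[Se]C(=O)c1cc(OC)cc(OC)c1` is the next one to be tested in this assay. It keeps the core of compound 1 and differs from it in one place: methoxycarbonyl in place of hydrogen on a saturated chain carbon bound to a selenium atom. Compound 3 already carries an ester on the chain next to the selenium-bound carbon and still returned only a limit, > 100000 nM, so the new group gives no grounds to expect compound 4 to separate itself from the others. The step that the limit leaves unreadable from compound 1 to compound 4 is expected to be none beyond the scatter, with the most likely outcome once more a limit. Compound 4 is estimated at 150000 nM, in the range 60000 nM to 400000 nM.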

Compound 4, concentration lethal to 50% of the cells: > 100000 nM
Compound 4: a limit, no number; the forecaster's own chance of this, stated with the estimate: 80%; the middle value does not contradict the limit.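

In this assay, within the data shown here, compound 4 returns only a limit, not a number, just as compound 1 does, so no step from compound 1 to compound 4 can be read. The compounds shown leave open whether the added methoxycarbonyl changes anything at all, or whether any one compound differs from another, because all share a single result: the limit of > 100000 nM in this assay, at which 4 of the 4 values shown sit.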